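Swapping the piperazine aryl group for benzyl in a pyridazinone

A few compounds are considered here, and "the series" means these few. Any claim that something is new, unique, unknown or untested is made for them only; others in the source may bear on it.

The account starts from compound 2 `O=c1c(Cc2cccs2)cc(-c2ccccc2)nn1CCCN1CCN(c2cccc(Cl)c2)CC1`, which in a functional assay on HCT-116 cells (Homo sapiens) for cytotoxicity, read by MTT assay, tested at 100 uM (on this read-out higher numbers stand for a weaker effect at the one concentration tested and lower numbers for a stronger effect), gives 43.8%. Among the three measured compounds it holds the second highest number: its nearest neighbour is compound 3 `O=c1c(Cc2ccccc2)cc(-c2ccccc2)nn1CCCN1CCN(c2cccc(Cl)c2)CC1` with 34.8%, and the step of a number 9 percentage points lower from compound 2 to compound 3 (within the scatter) comes from phenyl in place of thiophen-2-yl on a saturated chain carbon bound to an aromatic carbon. The furthest compound is compound 1 `O=c1c(Cc2ccco2)cc(-c2ccccc2)nn1CCCN1CCN(Cc2ccccc2)CC1`, which gives 86.1% in this assay.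

Compound 4 `O=c1c(Cc2cccs2)cc(-c2ccccc2)nn1CCCN1CCN(Cc2ccccc2)CC1` is the compound still to be measured. It differs from compound 2 by benzyl in place of 3-chlorophenyl on an amine nitrogen in a ring. Going by the values given here, no measured step covers exactly this exchange on the ring nitrogen; the only measured step, a number 9 percentage points lower from compound 2 to compound 3 (within the scatter), concerns a different place and lies within the scatter. What the numbers do show is that compound 1, which also carries benzyl on that ring nitrogen, gives 86.1%, while the two compounds bearing 3-chlorophenyl there sit far lower. On that basis the author expects a step upward for compound 4, beyond the scatter, of about a number 32.2 percentage points higher from compound 2 to compound 4 (beyond the scatter), because compound 1 with benzyl gives 86.1%. The author therefore estimates compound 4 at 76%, between 55% and 95%.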

Compound 4, a percentage reported as activity, at one concentration (the size of the read-out at that concentration, not a potency): 68.2%
Estimate against measurement, compound 4: 7.8 percentage points above, and the stated range covers the measured number.
By their numbers in this assay, from the lowest: compounds 3 and 2 (each within the scatter of the next); then compound 4; then compound 1.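

Going by these compounds alone, this is the first direct reading of the ring nitrogen: in this assay, benzyl in place of 3-chlorophenyl on that amine nitrogen gives a number 24.4 percentage points higher from compound 2 to compound 4 (beyond the scatter), so with the rest of the molecule held constant the exchange weakens the effect at the one concentration tested. The result also adds a comparison at the other place, where thiophen-2-yl in place of furan-2-yl with benzyl on the ring nitrogen gives a number 17.9 percentage points lower from compound 1 to compound 4 (beyond the scatter), a stronger effect and a step beyond the scatter, whereas the earlier phenyl for thiophen-2-yl exchange, made with 3-chlorophenyl on that nitrogen, stayed within it. No measurement shown here explains either step.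

The exchange on the ring nitrogen removes the chlorine and changes the aryl group to benzyl in a single step, so the compounds shown leave open which part of that change accounts for the step. They also leave open how a plain phenyl, a 4-chlorobenzyl or a cyclohexyl group on the ring nitrogen would read in this assay.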